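The source may report more compounds than this note shows. Statements on the series, on what has been measured and on what is new or still open speak of the compounds shown alone.

Compound 1 `CCCCn1cnc2c(Nc3cccc(Cl)c3)nc(N[C@H]3CC[C@H](N)CC3)nc21` gives 5100 nM
Compound 2 `CC(C)=CCn1cnc2c(Nc3cccc(Cl)c3)nc(N[C@H]3CC[C@H](N)CC3)nc21` gives 7000 nM
Compound 3 `CC(C)CCn1cnc2c(Nc3cccc(Cl)c3)nc(N[C@H]3CC[C@H](N)CC3)nc21` is not yet measured

Among the compounds with values here, in a functional assay on BT-474 cells (Homo sapiens) for inhibition, read by fluorescence, with a stated time of 72 h (on this read-out higher numbers stand for weaker inhibition of growth and lower numbers for stronger inhibition of growth), only two numbers exist so far. Compound 2 holds the larger of them, but the step of a 1.4-fold higher number from compound 1 to compound 2 (0.14 log units; within the scatter) lies within the scatter, so the two compounds cannot be told apart on this read-out. Compound 3 differs from compound 2 in one place: isobutyl in place of 2-methylprop-1-en-1-yl on a saturated chain carbon bound to an aromatic nitrogen. Within the data shown here, the one measured step that bears on this change is a 1.4-fold higher number from compound 1 to compound 2 (0.14 log units; within the scatter), which exchanged propyl for 2-methylprop-1-en-1-yl at the same place and left the number essentially where it was. Removing the double bond outside aromatic rings while keeping a chain of the same size is therefore expected to give no step beyond the scatter. Compound 3 is expected to give 6000 nM, with a range from 3000 nM to 12000 nM. The expected step from compound 2 is a 1.2-fold lower number from compound 2 to compound 3 (0.07 log units; within the scatter).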

Compound 3, concentration for 50% growth inhibition: 3800 nM
The estimate for compound 3 lay 1.6-fold (0.20 log units) above the measured number; measured number inside the range.
By their numbers in this assay, from the lowest: compounds 3, 1 and 2 (each within the scatter of the next).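

Removing the double bond outside aromatic rings at this place, with isobutyl in place of 2-methylprop-1-en-1-yl, leaves compound 3 within the scatter of compound 2 in this assay (a 1.8-fold lower number from compound 2 to compound 3 (0.27 log units; within the scatter)). A methyl in place of hydrogen on a saturated chain carbon bound to two saturated chain carbons also stays within the scatter (a 1.3-fold lower number from compound 1 to compound 3 (0.13 log units; within the scatter)), so a branch on the saturated chain and a double bond in it both leave the three compounds indistinguishable on this read-out. Nothing available explains why these chains behave alike, and no measurement beyond the growth numbers bears on this result.

All three chains consist of carbon and hydrogen only, so the compounds shown leave open what an amine, a carboxylic acid or a phenyl ring at this place would do. They also leave open whether a much longer chain or a single methyl would move the number beyond the scatter.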